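Phenyl in Place of Allyl on an Aromatic Nitrogen

The source may report more compounds than this note shows. Statements on the series, on what has been measured and on what is new or still open speak of the compounds shown alone.

Compound 1, `COc1ccc(-c2nnc(SCC(=O)Nc3ccc(/C(C)=N/O)cc3)n2-c2ccccc2)cc1OC`: 79%
Compound 2, `C=CCn1c(SCC(=O)Nc2ccc(/C(C)=N/O)cc2)nnc1-c1ccc(OC)c(OC)c1`: 79%
Compound 3, `C=CCn1c(SCC(=O)Nc2ccc(C(C)=O)cc2)nnc1-c1ccc(OC)cc1`: 68%

All three were read in a functional assay on the whole organism (strain albino) for inhibition, with Rattus norvegicus as the target, read by paw edema, with stated times of 30 min and 4 h, at a dose of 0.28 mmol/kg by the oral route; on this read-out lower numbers stand for less inhibition and higher numbers for more inhibition at the one dose given (going by the name of the read-out). Compound 2 and compound 1 differ by phenyl in place of allyl on an aromatic nitrogen, and the step is no change at the digits printed from compound 2 to compound 1 (within the scatter). Compound 3 gives the lowest of the three numbers, beyond the scatter from both compound 1 and compound 2. How the core of compound 3 differs from the core of compound 2 is not broken down here.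

Compound 4, `COc1ccc(-c2nnc(SCC(=O)Nc3ccc(C(C)=O)cc3)n2-c2ccccc2)cc1`, is not yet measured; it differs from compound 3 by phenyl in place of allyl on an aromatic nitrogen. This is the same kind of change as that from compound 2 to compound 1, but the ring atom next to the place bears a 4-methoxyphenyl group (8 heavy atoms) rather than a 3,4-dimethoxyphenyl group. Because the earlier change gave no change at the digits printed from compound 2 to compound 1 (within the scatter), the step from compound 3 to compound 4 is expected to be no change at the digits printed from compound 3 to compound 4 (within the scatter). Compound 4 is therefore estimated at 68%, with a likely range from 58% to 78%.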

Compound 4, a percentage reported as inhibition, in the whole organism at one dose (the size of the read-out at that dose, not a potency): 63%
Beside the measured number, compound 4's estimate is 5 percentage points above it; low and high end bracket the measured number.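

In this assay, phenyl in place of allyl on an aromatic nitrogen gives a number 5 percentage points lower from compound 3 to compound 4 (within the scatter), and the two cores agree on this change: the same change on two cores in this assay, no change at the digits printed (within the scatter) from compound 2 to compound 1 and a number 5 percentage points lower (within the scatter) from compound 3 to compound 4, 5 percentage points apart, within the scatter of two such steps. The swap therefore carried from the core of compound 2 to the core of compound 3 with no step beyond the scatter. Among the compounds shown here, this rests on only two pairs, each read at a single dose, so it shows neither why the swap leaves the read-out within the scatter nor that it would do so on any other core.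

The compounds shown leave open whether a longer chain, a benzyl group or a chain ending in an amine on that nitrogen would behave as allyl and phenyl do.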